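The source may report more compounds than this note shows. Statements on the series, on what has been measured and on what is new or still open speak of the compounds shown alone.

Compound 2 `CC/C=C(\CCC)C(=O)O` gives the lowest number of the three in a functional assay on the whole organism with Mus musculus as the target (on this read-out lower numbers stand for an effect already at smaller amounts and higher numbers for an effect only at larger amounts of compound), at 0.84 umol/kg. Compound 3 `CC/C=C(\CCCC)C(=O)O` gives 0.87 umol/kg, and the step of a 1.0-fold higher number from compound 2 to compound 3 (0.02 log units; within the scatter) is within the scatter. Compound 1 `CC/C=C(\CC)C(=O)O` gives 1.6 umol/kg, and the step of a 1.9-fold lower number from compound 1 to compound 2 (0.28 log units; within the scatter) also stays within the scatter, as does a 1.8-fold lower number from compound 1 to compound 3 (0.26 log units; within the scatter). Compound 4 `C/C=C\C(=C/CC)C(=O)O` differs from compound 2 by prop-1-en-1-yl in place of propyl on a double-bonded chain carbon bound to a carbonyl carbon and a double-bonded chain carbon. Among the measured compounds shown here, none of the measured steps touches this part of the structure; all three alter only saturated chain carbons, and none left the scatter. There is thus no basis for expecting a large step, so for compound 4 the expected step is a 1.1-fold higher number from compound 2 to compound 4 (0.03 log units; within the scatter). Compound 4 is estimated at 0.9 umol/kg, in the range 0.4 umol/kg to 2 umol/kg.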

Compound 4, dose for half-maximal effect: 0.78 umol/kg
Estimate against measurement, compound 4: 1.2-fold (0.06 log units) above, within the range that was stated.
By their numbers in this assay, from the lowest: compounds 4, 2, 3 and 1 (each within the scatter of the next, the first and the last beyond it).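

In this assay, among the compounds shown here, prop-1-en-1-yl in place of propyl gives a 1.1-fold lower number from compound 2 to compound 4 (0.03 log units; within the scatter) and so shows that a double bond can enter this chain with no step that stands out from the scatter. The same group in place of ethyl gives a 2.1-fold lower number from compound 1 to compound 4 (0.31 log units; beyond the scatter) and is a modest step, the only one here beyond the scatter. Nothing at hand explains either step. On these data alone, how an amine, a hydroxyl group or a phenyl ring on this double-bonded chain carbon would behave stays open.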